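Glucagon receptor binding: aryl swap on the imine carbon

This account rests on a few compounds, and the source may have more. Where it says the series, first, only, none or still open, it means among the compounds named here.

Measured so far:
compound 1, `C[C@H](c1ccc(C(=O)NCCC(=O)O)cc1)N1C(=O)C(c2cccc(Cl)c2)=N[C@]12CC[C@@H](C(C)(C)C)CC2` — 3300 nM
compound 2, `CC(C)(C)[C@H]1CC[C@]2(CC1)N=C(c1ccc(C(F)(F)F)cc1)C(=O)N2Cc1ccc(C(=O)NCCC(=O)O)cc1` — 9600 nM

In an assay on membranes from liver for displacement of a labelled ligand from Glucagon receptor (Mus musculus), read by scintillation counting, with a stated time of 60 min (on this read-out lower numbers stand for stronger inhibition and higher numbers for weaker inhibition), compound 2 gives 9600 nM, the higher of the two numbers recorded; compound 1 gives 3300 nM, and the gap between the two lies beyond the usual scatter. Within the data shown here, the two compounds differ in more than one place, so no single step between them is recorded.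

Compound 3, `CC(C)(C)[C@H]1CC[C@]2(CC1)N=C(c1cccc(Cl)c1)C(=O)N2Cc1ccc(C(=O)NCCC(=O)O)cc1`, is the next member: 3-chlorophenyl in place of 4-(trifluoromethyl)phenyl on a carbon with a double bond to nitrogen. Compound 1 already carries a 3-chlorophenyl on the same carbon of the shared core, but it also differs from compound 3 elsewhere on the nitrogen substituent, so its value is only a partial guide. The expected step from compound 2 to compound 3 is a 2.1-fold lower number from compound 2 to compound 3 (0.33 log units; beyond the scatter), a move toward a lower number that may or may not clear the scatter. Compound 3 is estimated at 4500 nM, expected within 1500 nM to 14000 nM.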

Compound 3, half-maximal inhibitory concentration: > 10000 nM
Compound 3: only a limit was reported; the forecaster's own chance of this, stated with the estimate: 5%; middle value at least 2.2-fold (0.34 log units) away from the limit.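

Compound 3 gives only a limit of the assay, not a number: the limit of > 10000 nM in this assay, at which 1 of the 3 values shown sits.

With 3-chlorophenyl in place of 4-(trifluoromethyl)phenyl on the carbon with a double bond to nitrogen, the step reads as an at least 1.0-fold higher number from compound 2 to compound 3 (0.01 log units; that floor lies within the scatter), so the two aryl groups cannot yet be ordered at this position. Hydrogen in place of methyl on the saturated chain carbon reads as an at least 3.0-fold higher number from compound 1 to compound 3 (0.48 log units; beyond the scatter), which gives the first one-place comparison at that carbon and shows that the value of compound 1 does not carry over to its analogue without the methyl.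

As far as these compounds go, the true distance between compound 2 and compound 3 remains open, as does the effect of the aryl change with the methyl present. An ethyl group on the chain carbon, or a 4-chlorophenyl on the carbon with a double bond to nitrogen, would test how far each trend extends.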